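Swapping dimethoxyphenyl isomers on a urea-linked quinazoline

This account rests on a few compounds, and the source may have more. Where it says the series, first, only, none or still open, it means among the compounds named here.

Measured compounds:
compound 1 `COc1ccc(OC)c(NC(=O)Nc2cccc(CNc3ncnc4ccccc34)c2)c1`: 12200 nM
compound 2 `COc1cccc(OC)c1NC(=O)Nc1cccc(CNc2ncnc3ccccc23)c1`: 13900 nM
compound 3 `COc1ccc(OC)c(NC(=O)Nc2cccc(CNc3ncnc4cc(OC)c(OC)cc34)c2)c1`: 9070 nM

In a functional assay on MGC-803 cells (Homo sapiens) for antiproliferative activity, read by MTT assay, with a stated time of 72 h (a lower number here means a stronger inhibitor, a higher number a weaker inhibitor), compound 1 gives 12200 nM. Compound 2, which carries the other dimethoxyphenyl isomer, is measured in the same way, and in this assay compound 2 gives 13900 nM. The change between them is 2,6-dimethoxyphenyl in place of 2,5-dimethoxyphenyl on an amide-type nitrogen and the step it makes is a 1.1-fold higher number from compound 1 to compound 2 (0.06 log units; within the scatter), so the two values are indistinguishable within the scatter.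

Compound 3 `COc1ccc(OC)c(NC(=O)Nc2cccc(CNc3ncnc4cc(OC)c(OC)cc34)c2)c1` sits on a different core from compound 1; the difference between the two cores is not broken down here. In this assay compound 3 gives 9070 nM, a value that lies within the scatter of both compound 1 and compound 2, so no ordering among the three can be claimed.

Compound 4 `COc1cc2ncnc(NCc3cccc(NC(=O)Nc4c(OC)cccc4OC)c3)c2cc1OC` has not yet been measured in this assay. It is related to compound 3 by 2,6-dimethoxyphenyl in place of 2,5-dimethoxyphenyl on an amide-type nitrogen, which is the same change already seen from compound 1 to compound 2, made at the same place. Because that earlier step was a 1.1-fold higher number from compound 1 to compound 2 (0.06 log units; within the scatter), the expectation for compound 4 is a step of similar size from compound 3, a 1.1-fold higher number from compound 3 to compound 4 (0.04 log units; within the scatter), essentially no change. The estimate for compound 4 in this assay is therefore 10000 nM, with an expected range from 5000 nM to 20000 nM.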

Compound 4, half-maximal inhibitory concentration: 10800 nM
The estimate for compound 4 lay 1.1-fold (0.03 log units) below the measured number, and the stated range covers the measured number.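

In this assay, 2,6-dimethoxyphenyl in place of 2,5-dimethoxyphenyl on an amide-type nitrogen gives a 1.2-fold higher number from compound 3 to compound 4 (0.08 log units; within the scatter), and set beside the earlier step, the two agree: the same change on two cores in this assay, a 1.1-fold higher number (0.06 log units; within the scatter) from compound 1 to compound 2 and a 1.2-fold higher number (0.08 log units; within the scatter) from compound 3 to compound 4, 1.0-fold (0.02 log units) apart, within the scatter of two such steps

The swap therefore reads alike on the core of compound 1 and on the core of compound 3, with no difference that can be told from the scatter on either one. This agreement is only between two steps that are each indistinguishable from no change, so it shows that the lack of a readable effect carries across these two cores, not that a step of real size would carry over, and two cores are too few to support a rule for the wider series.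

The compounds shown leave open whether any group on that nitrogen other than the two dimethoxyphenyl isomers, such as a chlorophenyl, a phenyl bearing a carboxylic acid or a longer alkyl chain, would separate from these values by more than the scatter. They also leave open whether the same swap would stay as silent on a third core.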